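From 2,6-dichlorophenyl to phenyl on the shared core

The source may hold more compounds than are shown below. What is called first, only, known or untested is meant among the compounds shown, and "the series" means these compounds.

In a functional assay on SW-620 cells (Homo sapiens) for cytotoxicity, read by sulforhodamine B assay, with a stated time of 48 h (a higher number here means a weaker inhibitor, a lower number a stronger inhibitor), compound 1 `C[C@H]1CC[C@@H]2[C@@H](OC(=O)[C@]23CC(c2c(Cl)cccc2Cl)=NO3)[C@]2(C)C(=O)C=C[C@@]12O` gives 43000 nM. Among the compounds with values here, compound 2 `C[C@H]1CC[C@@H]2[C@@H](OC(=O)[C@]23CC(c2ccc(Cl)cc2)=NO3)[C@]2(C)C(=O)C=C[C@@]12O` gives 51000 nM, so compound 1 stands within the scatter of the only other measured number. Compound 3 `C[C@H]1CC[C@@H]2[C@@H](OC(=O)[C@]23CC(c2ccccc2)=NO3)[C@]2(C)C(=O)C=C[C@@]12O` has not yet been measured. It carries phenyl in place of 2,6-dichlorophenyl on a carbon with a double bond to nitrogen. Within the data shown here, one measured step bears on this change: putting 4-chlorophenyl in place of 2,6-dichlorophenyl at the same carbon gives a 1.2-fold higher number from compound 1 to compound 2 (0.07 log units; within the scatter). Among the measured compounds shown here, that step is small, but no measured compound lacks chlorine, so the evidence is thin. No step beyond the scatter is therefore expected in this assay. The estimated change is a 1.1-fold higher number from compound 1 to compound 3 (0.04 log units; within the scatter), which would stay within the scatter. For compound 3 the expected value is 47000 nM, with an estimated range from 25000 nM to 90000 nM.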

Compound 3, half-maximal inhibitory concentration: 45400 nM
Beside the measured number, compound 3's estimate is 1.0-fold (0.02 log units) above it; the measured number falls inside the stated range.
By their numbers in this assay, from the lowest: compounds 1, 3 and 2 (each within the scatter of the next).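

In this assay phenyl in place of 2,6-dichlorophenyl gives a 1.1-fold higher number from compound 1 to compound 3 (0.02 log units; within the scatter) and hydrogen in place of chloro on the aromatic carbon gives a 1.1-fold lower number from compound 2 to compound 3 (0.05 log units; within the scatter) within this set. The earlier pair both carried chlorine, whereas compound 3 carries none, so these steps show that, for these three compounds, chlorine on the phenyl ring on a carbon with a double bond to nitrogen makes no difference beyond the scatter. Nothing available gives a reason for this flat result. The compounds shown leave open whether anything other than a plain or chlorinated phenyl at this carbon would move the number beyond the scatter. A pyridine ring, a phenyl bearing an amine or a carboxylic acid, or a longer chain in its place would each test that.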